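The source may hold more compounds than are shown below. What is called first, only, known or untested is meant among the compounds shown, and "the series" means these compounds.

In a functional assay on brain (Rattus norvegicus, strain Wistar) for inhibition (a lower number here means a stronger inhibitor, a higher number a weaker inhibitor), compound 1 `CCCCOc1ccc(-c2c(C)[nH]c(=O)n2C)cc1` gives 5100 nM and stands level, within the scatter, with compound 2 `CCCCCCc1ccc(-c2c(C)[nH]c(=O)n2C)cc1` at 9000 nM and compound 3 `Cc1[nH]c(=O)n(C)c1-c1ccc(C2CCCCC2)cc1` at 10000 nM on the same scale. Within the data shown here, compound 4 `CCCCCCCOc1ccc(-c2c(C)[nH]c(=O)n2C)cc1` lengthens the butoxy chain of compound 1 through the change propyl in place of hydrogen on a saturated chain carbon, four bonds along the chain from an oxygen on an aromatic ring and no measured step tests that change directly. The closest evidence comes from swaps of the group on an aromatic carbon, where a 2.0-fold higher number from compound 1 to compound 3 (0.29 log units; within the scatter) and a 1.1-fold higher number from compound 2 to compound 3 (0.05 log units; within the scatter) stay within the scatter. With a 1.8-fold higher number from compound 1 to compound 2 (0.25 log units; within the scatter) also within the scatter, no step beyond it is expected in this assay for this longer chain. The estimated step is a 1.1-fold lower number from compound 1 to compound 4 (0.05 log units; within the scatter) and it is expected to stay inside the scatter. For compound 4 the estimated value is 4500 nM with an expected range from 1500 nM to 12000 nM in this measurement.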

Compound 4, half-maximal inhibitory concentration: 5700 nM
Estimate against measurement, compound 4: 1.3-fold (0.10 log units) below; the range from low to high includes it.
By their numbers in this assay, from the lowest: compounds 1, 4, 2 and 3 (each within the scatter of the next).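

In this assay, the first direct test of this position, propyl in place of hydrogen on the butoxy chain gives a 1.1-fold higher number from compound 1 to compound 4 (0.05 log units; within the scatter) and so leaves compound 4 level with compound 1. The earlier compounds shown here only exchanged the whole group on the aromatic carbon, whereas this pair shows that extending the chain itself, with the oxygen kept, also stays within the scatter. Nothing available accounts for this flat result.

Going by these compounds, whether a longer chain would stay level remains open. So does the effect of an amine or a carboxylic acid at the chain end.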